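The source may report more compounds than this note shows. Statements on the series, on what has been measured and on what is new or still open speak of the compounds shown alone.

Measured compounds:
compound 1 `O=c1ccoc2cc(OCc3cn(Cc4cccc(Cl)c4)nn3)ccc12` — 28400 nM
compound 2 `O=c1ccoc2cc(OCc3cn(Cc4ccccc4Cl)nn3)ccc12` — 19700 nM

In a functional assay on QGY7701 cells (Homo sapiens) for cytotoxicity, read by MTT assay, with a stated time of 48 h (a higher number here means a weaker inhibitor, a lower number a stronger inhibitor), compound 2 and compound 1 stand within the scatter of each other; the step of a 1.4-fold lower number from compound 1 to compound 2 (0.16 log units; within the scatter) separates them, nothing more. Compound 3 `N#Cc1cccc(Cn2cc(COc3ccc4c(=O)ccoc4c3)nn2)c1` differs from compound 2 by 3-cyanophenyl in place of 2-chlorophenyl on a saturated chain carbon bound to an aromatic nitrogen. Among the compounds with values here, the only measured step bearing on this change is a 1.4-fold lower number from compound 1 to compound 2 (0.16 log units; within the scatter), which also alters the group on the saturated chain carbon bound to an aromatic nitrogen, and it stayed within the scatter; no measured step replaces chlorine with a nitrile. The expected step is therefore none beyond the scatter: a 1.1-fold higher number from compound 2 to compound 3 (0.05 log units; within the scatter). Compound 3 is estimated at 22000 nM, with a range from 9000 nM to 55000 nM.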

Compound 3, half-maximal inhibitory concentration: 24400 nM
The estimate for compound 3 lay 1.1-fold (0.04 log units) below the measured number, and the stated range covers the measured number.
By their numbers in this assay, from the lowest: compounds 2, 3 and 1 (each within the scatter of the next).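

In this assay, 3-cyanophenyl in place of 2-chlorophenyl on a saturated chain carbon bound to an aromatic nitrogen gives a 1.2-fold higher number from compound 2 to compound 3 (0.09 log units; within the scatter) and stays within the scatter. Cyano in place of chloro on an aromatic carbon gives a 1.2-fold lower number from compound 1 to compound 3 (0.07 log units; within the scatter) as the first measured exchange of chlorine for a nitrile, and this step also stays within the scatter. Nothing measured here offers an explanation for these results.

As far as these compounds go, whether an amine or a carboxylic acid in place of the nitrile would give a step beyond the scatter remains open. The compounds shown also leave open whether any change to the shared core would do so.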